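Fluoro in Place of Chloro: Two Matched Pairs

A few compounds are considered here, and "the series" means these few. Any claim that something is new, unique, unknown or untested is made for them only; others in the source may bear on it.

Compound 1 `CCOC(=O)c1oc2ccc(NS(=O)(=O)c3ccc(Cl)cc3)cc2c1C`: > 40000 nM
Compound 2 `CCOC(=O)c1oc2ccc(NS(=O)(=O)c3ccc(F)cc3)cc2c1C`: > 40000 nM
Compound 3 `Cc1c(C(=O)O)oc2ccc(N(Cc3ccccc3)S(=O)(=O)c3ccc(Cl)cc3)cc12`: 33400 nM

In a functional assay on HCT-116 cells (Homo sapiens) for inhibition, read by MTT assay, with a stated time of 72 h (a lower number here means a stronger inhibitor, a higher number a weaker inhibitor), compound 1 gives > 40000 nM, which is a limit of the assay rather than a number. Compound 2 gives > 40000 nM, again a limit. Going by the values given here, compound 3 gives 33400 nM, the only number among the three. Compound 2 differs from compound 1 by fluoro in place of chloro on an aromatic carbon; the step that the two limits leave unreadable from compound 1 to compound 2 cannot be read, since (the limit of > 40000 nM in this assay, at which 2 of the 3 values shown sit). How the core of compound 1 differs from the core of compound 3 is not broken down here.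

Compound 4 `Cc1c(C(=O)O)oc2ccc(N(Cc3ccccc3)S(=O)(=O)c3ccc(F)cc3)cc12` is not yet measured. It differs from compound 3 by fluoro in place of chloro on an aromatic carbon, the same change as from compound 1 to compound 2, at the same place. Since that earlier step gave no readable size, the step of a 1.0-fold higher number from compound 3 to compound 4 (0.02 log units; within the scatter) is expected to be small. Compound 4 is estimated at 35000 nM, between 15000 nM and 80000 nM.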

Compound 4, half-maximal inhibitory concentration: > 40000 nM
Compound 4: a limit, no number; the forecaster's own chance of this, stated with the estimate: 40%; middle value at least 1.1-fold (0.05 log units) away from the limit.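

In this assay compound 4 gives > 40000 nM, which is a limit and not a number. Fluoro in place of chloro therefore gives an at least 1.1-fold higher number from compound 3 to compound 4 (0.07 log units; that floor lies within the scatter), a floor with no upper end, so the real size of the step stays unknown. The same change on the core of compound 1 cannot be read either, and whether the change carries from one core to the other stays unsettled because no step has a full size to compare: the limit of > 40000 nM in this assay, at which 3 of the 4 values shown sit.

The compounds shown leave open what an amine or a methoxy group would do in place of the halogen on this ring. They also leave open whether any such group would bring a readable number in this assay.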